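The source may hold more compounds than are shown below. What is called first, only, known or untested is meant among the compounds shown, and "the series" means these compounds.

The account begins with two compounds tested for inhibition of growth of prostate carcinoma cells. Compound 1 `O=C(/C(=C\c1ccc(O)cc1O)Sc1ccc(Br)cc1)c1ccc(Cl)cc1`, in a functional assay on DU-145 cells (Homo sapiens) for inhibition, read by trypan blue exclusion, with a stated time of 96 h (a lower number here means a stronger inhibitor of growth, a higher number a weaker inhibitor of growth), gives 50000 nM. Compound 2 `Cc1ccc(CS/C(=C/c2ccc(O)c(O)c2O)C(=O)c2ccc(Cl)cc2)cc1` gives, in this assay, 50000 nM. Compound 2 stands level with compound 1 at the digits shown: the two values lie within the ordinary scatter of repeated measurements, so no order between them can be read from these numbers. Both compounds share one core, and both are weak inhibitors of growth in this cell line on the concentration scale of this measurement.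

Compound 3 `Cc1ccc(CS/C(=C/c2ccc(N(C)C)cc2)C(=O)c2ccc(Cl)cc2)cc1` has not yet been measured. It differs from compound 2 in a single place: 4-(dimethylamino)phenyl in place of 2,3,4-trihydroxyphenyl on a double-bonded chain carbon bound to a double-bonded chain carbon. Within the data shown here, no step between measured compounds is available to guide this change, and neither compound 1 nor compound 2 carries the entering group. Without such a step, the expected movement in this assay is none beyond the scatter, in either direction, for the step of no change at the digits printed from compound 2 to compound 3 (within the scatter). Compound 3 is therefore estimated to give 50000 nM, in a range of 15000 nM to 100000 nM.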

Compound 3, concentration for 50% growth inhibition: > 100000 nM
Compound 3 was reported as a limit (the forecaster's own chance of this, stated with the estimate: 35%); middle value at least 2.0-fold (0.30 log units) from the limit.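

In this assay compound 3 gives > 100000 nM, which is a limit of the assay and not a number. Going by these compounds, on a double-bonded chain carbon bound to a double-bonded chain carbon, 4-(dimethylamino)phenyl in place of 2,3,4-trihydroxyphenyl gives an at least 2.0-fold higher number from compound 2 to compound 3 (0.30 log units; that floor lies within the scatter), so this first readable change at the position brings no gain in inhibition of growth, although the true size of the step remains unknown. The aromatic ring and the count of 9 heavy atoms stay the same while 3 hydrogen-bond donors give way to 0, yet this reading has only a floor to stand on: the limit of > 100000 nM in this assay, at which 1 of the 3 values shown sits.

The compounds shown leave open whether the step goes with the departure of the hydroxyl groups or with the arrival of the dimethylamino group, since both happen in this one exchange. A 4-methoxyphenyl or a 4-aminophenyl group at the same place would separate these two readings, and a shared limit or a measurable value for either would show how far this position can move growth inhibition in this assay.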